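This account rests on a few compounds, and the source may have more. Where it says the series, first, only, none or still open, it means among the compounds named here.

Compound 1 `Nc1nc2c(Cl)c(Cl)ccc2n1COC(CO)CO` and compound 2 `OCC(CO)OCn1c(SCc2ccccc2)nc2c(Cl)c(Cl)ccc21` share one core and differ at a single aromatic carbon. In a functional assay on KB cells (Homo sapiens) for inhibition (on this read-out higher numbers stand for weaker inhibition and lower numbers for stronger inhibition), compound 1 reaches only > 100000 nM, which is a limit of the assay rather than a number. In this assay, for the measured compounds named here, compound 2 gives 60000 nM, the only real number among the two values shown, the other being (the limit of > 100000 nM in this assay, at which 1 of the 2 values shown sits). The step of an at least 1.6-fold lower number from compound 1 to compound 2 (0.22 log units; that floor lies within the scatter) came with benzylsulfanyl in place of amino on an aromatic carbon.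

Compound 3 `OCC(CO)OCn1cnc2c(Cl)c(Cl)ccc21` differs from compound 2 by hydrogen in place of benzylsulfanyl on an aromatic carbon. Going by the values given here, the only measured step that bears on this change is the one from compound 1 to compound 2, which removes the same benzylsulfanyl in reverse, though hydrogen rather than amino takes its place. Since that step's floor lies within the scatter, the expected change is small, with the number for compound 3 expected to drift upward, toward the limit, by about a 1.7-fold higher number from compound 2 to compound 3 (0.22 log units; within the scatter). Compound 3 is therefore estimated at 100000 nM, with a likely range from 40000 nM to 300000 nM.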

Compound 3, half-maximal inhibitory concentration: > 100000 nM
Compound 3: only a limit was reported; the forecaster's own chance of this, stated with the estimate: 55%; the middle value sits exactly at the limit.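

In this assay, replacing benzylsulfanyl with hydrogen on the aromatic carbon between two ring nitrogen atoms gives an at least 1.6-fold higher number from compound 2 to compound 3 (0.22 log units; that floor lies within the scatter). Hydrogen at this position thus ends at the same limit as amino, and of the three groups only benzylsulfanyl gives a real number, although the floor of that step does not establish a true difference. The step between compound 1 and compound 3 cannot be read, as both of their values are limits: the limit of > 100000 nM in this assay, at which 2 of the 3 values shown sit.

From the compounds shown here alone, it remains open whether the sulfur or the six-membered aromatic ring of benzylsulfanyl accounts for compound 2 giving a number. Equally open, going by these compounds, is whether a methylsulfanyl group, a phenyl ring joined directly to this carbon or a carboxylic acid would move the number beyond the scatter.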